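The source may report more compounds than this note shows. Statements on the series, on what has been measured and on what is new or still open speak of the compounds shown alone.

Compound 1: `CC1=C(C(=O)Nc2ccc([N+](=O)[O-])cc2)C(c2ccc(Br)cc2)N=C(SCc2ccccc2Cl)N1`, 16.9%. Compound 2: `CC1=C(C(=O)Nc2ccc([N+](=O)[O-])cc2)C(c2ccc(Br)cc2)N=C(SCc2cccc(Cl)c2)N1`, 9.2%. Compound 3: `CC1=C(C(=O)Nc2ccc([N+](=O)[O-])cc2)C(c2ccc(Br)cc2)N=C(SCc2ccc(Cl)cc2)N1`, not yet measured.

In a functional assay on the whole organism (artery, strain albino) with Rattus norvegicus as the target, with a stated time of 300 min, at a dose of 10 mg/kg by the oral route (on this read-out lower numbers stand for less inhibition and higher numbers for more inhibition at the one dose given (going by the name of the read-out)), compound 2 gives 9.2%, the lowest of the two numbers, with compound 1 the nearest at 16.9%, within the scatter. Compound 3 differs from compound 2 by 4-chlorophenyl in place of 3-chlorophenyl on a saturated chain carbon bound to a sulfur. For the measured compounds named here, the one measured step of this kind, a number 7.7 percentage points lower from compound 1 to compound 2 (within the scatter), stayed within the scatter, so the move to the 4-chlorophenyl is expected to bring no change beyond the scatter in this assay. Compound 3 is therefore estimated at 12%, between 0% and 28%, an expected step of a number 2.8 percentage points higher from compound 2 to compound 3 (within the scatter).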

Compound 3, a percentage reported as inhibition, in the whole organism at one dose (the size of the read-out at that dose, not a potency): 37.9%
Compound 3: middle estimate off by 25.9 percentage points, on the low side; the measured number lies above the stated range.
By their numbers in this assay, from the lowest: compounds 2 and 1 (each within the scatter of the next); then compound 3.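

At this position, on a saturated chain carbon bound to a sulfur, the place of the chlorine on the chlorophenyl matters in this assay: the data show a number 28.7 percentage points higher from compound 2 to compound 3 (beyond the scatter) and a number 21 percentage points higher from compound 1 to compound 3 (beyond the scatter) and both steps lie beyond the scatter, which the earlier pair of compounds did not show. Compound 3 has the same atoms as the other two, joined differently, so rearrangement alone moves the number. Nothing given here bears on why this happens.

The compounds shown leave open whether chlorine itself is needed, since a 4-fluorophenyl, a 4-methoxyphenyl or a plain phenyl at this position is not among them.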